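This account rests on a few compounds, and the source may have more. Where it says the series, first, only, none or still open, it means among the compounds named here.

Measured so far in an assay on cells for displacement of a labelled ligand from corticotropin-releasing factor receptor 1 (Homo sapiens), with a stated time of 100 min; a higher number here means a weaker inhibitor, a lower number a stronger inhibitor:
compound 1 `CCCN(CC1CC1)C(=O)c1c(C)nc2n(-c3c(C)cc(C)cc3C)c(Cl)cn12`, 61 nM
compound 2 `CCCN(CCC(F)(F)F)Cc1c(C(F)(F)F)nc2n(-c3c(C)cc(C)cc3C)c(Cl)cn12`, 12 nM
compound 3 `CCCCN(C)Cc1c(C(F)(F)F)nc2n(-c3c(C)cc(C)cc3C)c(Cl)cn12`, 310 nM

Compound 3 stands at the highest number of the three, so it is the weakest inhibitor of the set in this assay; compound 1 lies nearest and compound 2 furthest from it, both beyond the scatter.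

The next compound, compound 4 `CCN(Cc1c(C(F)(F)F)nc2n(-c3c(C)cc(C)cc3C)c(Cl)cn12)CC1CCC1`, is reached from compound 3 by one change on the saturated chain carbon bound to an aromatic carbon: (cyclobutylmethyl)(ethyl)amino in place of butyl(methyl)amino on a saturated chain carbon bound to an aromatic carbon. The amine keeps one acceptor and gains a four-membered ring, with both branches on nitrogen longer than a methyl.

Among the compounds with values here, one measured step bears on this position. It runs a 26-fold higher number from compound 2 to compound 3 (1.41 log units; beyond the scatter), and in that direction two longer branches on the amine nitrogen were replaced by a butyl and a methyl. Compound 4 moves back toward two longer branches, though with a ring rather than a fluorinated chain, so the step is expected to go in the opposite direction to that one, toward a lower number, and to be large but probably not to recover all of it.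

Compound 4 is therefore expected to reach about 45 nM in this assay, in the range 12 nM to 160 nM, an expected step of a 6.9-fold lower number from compound 3 to compound 4 (0.84 log units; beyond the scatter).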

Compound 4, inhibition constant: 16 nM
Estimate against measurement, compound 4: 2.8-fold (0.45 log units) above; measured number inside the range.
By their numbers in this assay, from the lowest: compounds 2 and 4 (each within the scatter of the next); then compound 1; then compound 3.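

In this assay, the change at the saturated chain carbon bound to an aromatic carbon gives a 19-fold lower number from compound 3 to compound 4 (1.29 log units; beyond the scatter), which shows that this position can respond strongly to an amine change even when the entering group contains no fluorine. Set against the earlier fluorinated amine, the same change gives a 1.3-fold higher number from compound 2 to compound 4 (0.12 log units; within the scatter), so the 3,3,3-trifluoropropyl chain of compound 2 is not required for a number in this range: the (cyclobutylmethyl)(ethyl)amino group of compound 4, which contains only carbon and nitrogen, sits level with it. Among compounds 2, 3 and 4, which differ only in this amine, the two with no methyl on nitrogen have the low numbers and the butyl(methyl)amino compound has the high one, with none of the three going against this.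

As far as these compounds go, both branches on nitrogen differ between compound 3 and compound 4, so the share of the step belonging to the ethyl branch and the share belonging to the cyclobutylmethyl branch stay open; a butyl(ethyl)amino or a (cyclobutylmethyl)(methyl)amino group at this position would separate them. Nothing available explains either step.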